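This account rests on a few compounds, and the source may have more. Where it says the series, first, only, none or still open, it means among the compounds named here.

Measured so far in a functional assay on MGC-803 cells (Homo sapiens) for cytotoxicity, read by MTT assay, with a stated time of 72 h; a lower number here means a stronger inhibitor, a higher number a weaker inhibitor:
- compound 1 `Cc1cc(N2CCNCC2)nc(SCc2nc3ccccc3[nH]2)n1`, reported only as a limit: > 100000 nM
- compound 2 `Cc1cc(Nc2cccc(C(F)(F)F)c2)nc(SCc2nc3ccccc3[nH]2)n1`, reported only as a limit: > 100000 nM

Compound 1 stands at a limit in this assay, not at a number. Within the data shown here, every value shown so far sits at that same limit (the limit of > 100000 nM in this assay, at which 2 of the 2 values shown sit), so there is no measured step from which a size could be read.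

Compound 3 `Cc1cc(Nc2ccc(F)cc2)nc(SCc2nc3ccccc3[nH]2)n1` differs from compound 1 in one place: (4-fluorophenyl)amino in place of piperazin-1-yl on an aromatic carbon. The shared core, the methyl group and the benzimidazolylmethylthio part are kept unchanged. With both measured values at the limit, no direction can be taken from the data, and the change in this assay is expected to be none beyond the scatter, most probably leaving compound 3 at the limit as well.

Compound 3 is therefore estimated at about 90000 nM, in a range from 20000 nM to 300000 nM. The expected step of an at least 1.1-fold lower number from compound 1 to compound 3 (0.04 log units; that floor lies within the scatter) is thus meant to lie within the scatter.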

Compound 3, half-maximal inhibitory concentration: 5770 nM
Compound 3: middle estimate off by 16-fold (1.19 log units), on the high side; measured number outside the range, below it.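

In this assay, the replacement of piperazin-1-yl by (4-fluorophenyl)amino on this aromatic carbon gives the first measurable activity in the series, with an at least 17-fold lower number from compound 1 to compound 3 (1.23 log units; beyond the scatter). An arylamino group at this place is not enough in itself: compound 2, which carries a trifluoromethyl-substituted phenylamino group there, remains at a limit of the assay, > 100000 nM. The full size of the step from piperazin-1-yl to (4-fluorophenyl)amino cannot be read, because compound 1 stands at a limit and the step is only a lower bound: the limit of > 100000 nM in this assay, at which 2 of the 3 values shown sit.

The compounds shown leave open whether the fluorine is needed, as an unsubstituted phenylamino group would show. They also leave open how a chlorine or methoxy group on that phenyl ring, or a morpholine or benzylamino group at the same place, would compare.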